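Cyclopentyl for Propyl on the Amino Nitrogen

A few compounds are considered here, and "the series" means these few. Any claim that something is new, unique, unknown or untested is made for them only; others in the source may bear on it.

Of the compounds shown here, three have been measured in an assay on isolated protein for binding affinity to adenosine receptor A1 (Bos taurus); on this read-out lower numbers stand for stronger inhibition and higher numbers for weaker inhibition. Compound 1 `CCCNc1nc(-c2ccccc2)nc2c1nnn2Cc1ccccc1` gives 37000000 nM, the second highest of the three numbers. Compound 2 `CNc1nc(-c2ccccc2)nc2c1nnn2Cc1ccccc1Cl` gives 191000000 nM in this assay, and compound 3 `OCCCNc1nc(-c2ccccc2)nc2c1nnn2Cc1ccccc1F` gives 3700000 nM, the lowest of the three. Compound 4 `c1ccc(Cn2nnc3c(NC4CCCC4)nc(-c4ccccc4)nc32)cc1` has not yet been measured. It differs from compound 1 in a single place: cyclopentyl in place of propyl on a nitrogen on an aromatic ring. Within the data shown here, no pair of measured compounds shares this change, so the expectation rests on the change itself. A moderate step toward a lower number, beyond the scatter, is expected, written as a 3.1-fold lower number from compound 1 to compound 4 (0.49 log units; beyond the scatter). Compound 4 is therefore estimated at 12000000 nM, within a range from 3000000 nM to 40000000 nM.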

Compound 4, inhibition constant: 11000000 nM
The estimate for compound 4 lay 1.1-fold (0.04 log units) above the measured number, and the stated range covers the measured number.
By their numbers in this assay, from the lowest: compound 3; then compound 4; then compound 1; then compound 2.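

In this assay, among these compounds, the change of propyl to cyclopentyl on a nitrogen on an aromatic ring gives a 3.4-fold lower number from compound 1 to compound 4 (0.53 log units; beyond the scatter) and is the only step that isolates this position, since compounds 1, 2 and 3 differ from one another in more than one place. It shows that a five-membered carbon ring can take the place of the open propyl chain here without the number rising. Nothing measured here accounts for this step.

On these data alone, it remains open whether a cyclohexyl or cyclobutyl ring, or a branched isopropyl chain, would move the number further or less far. As far as these compounds go, it is also open whether the same change would give a similar step on the core of compound 2 or compound 3.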